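The compounds below may be only part of what the source reports. "The series", "measured", "known", "first", "only" and "open" are said of these compounds alone.

Three compounds share a core bearing a sulfonyl group linked through a chain carbon to a small ring. Compound 1 `O=S(=O)(CC1=NCCO1)c1c(-c2ccc(Cl)cc2)nn(-c2ccccc2)c1-c1ccc(Cl)cc1` was tested in a functional assay, tested at 75 ug/mL (a lower number here means a weaker effect, a higher number a stronger effect of the compound at the concentration tested), and compound 1 is reported as "not active" (no number reported), so no single number places it on the scale. Compound 2 `COc1ccc(C2=NN(c3ccccc3)C(c3ccc(C)cc3)C2S(=O)(=O)CC2=NCCO2)cc1` gives 64.3% in this assay, and compound 3 `COc1ccc(-c2nn(-c3ccccc3)c(-c3ccc(C)cc3)c2S(=O)(=O)CC2=NCCO2)cc1` gives 68.7% in this assay; these two values lie within the usual scatter of each other.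

Compound 4 `O=S(=O)(CC1=NCCS1)c1c(-c2ccc(Cl)cc2)nn(-c2ccccc2)c1-c1ccc(Cl)cc1` has not yet been measured. It differs from compound 1 in one place: a group of 5 heavy atoms (3 carbon, 1 nitrogen, 1 sulfur; one five-membered non-aromatic ring with 2 hetero atoms) in place of a group of 5 heavy atoms (3 carbon, 1 nitrogen, 1 oxygen; one five-membered non-aromatic ring with 2 hetero atoms), on a saturated chain carbon bound to a sulfonyl sulfur. The ring that leaves and the ring that enters are of the same size, and the place on the saturated chain carbon bound to a sulfonyl sulfur is unchanged. For the measured compounds named here, no measured pair shows the size of such a step, so the effect in this assay is unknown; a small change, or none beyond the scatter, seems the most likely outcome, because compound 1 gives "not active" (no number reported). Compound 4 is therefore estimated at about 15%, in a range from 0% to 45%.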

Compound 4, a percentage reported as activity, at one concentration (the size of the read-out at that concentration, not a potency): "not active" (no number reported)
Compound 4: no number reported, and the estimate cannot be compared.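

Compound 1 and compound 4 both come without a number in this assay, so no step can be read between them. The compounds shown leave open whether the sulfur-containing ring differs at all from the oxygen-containing ring in this setting. No measurement shown here offers an explanation.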